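Working notes on a chloro addition in the series

The source may hold more compounds than are shown below. What is called first, only, known or untested is meant among the compounds shown, and "the series" means these compounds.

Three compounds are measured in a functional assay on COLO 205 cells (Homo sapiens) for cytotoxicity; on this read-out lower numbers stand for stronger inhibition and higher numbers for weaker inhibition. Compound 1 `Cc1c(S(=O)(=O)N/C(=N\O)Nc2ccc(Cl)cc2)sc2ccc(Cl)cc12` gives 60 ug/mL. Compound 2 `O=[N+]([O-])c1ccc(Oc2c(Cl)cc(S(=O)(=O)N/C(=N\O)Nc3ccc(Cl)cc3)cc2Cl)cc1` gives 12 ug/mL, and compound 3 `O=[N+]([O-])c1ccc(Oc2c(Cl)cc(S(=O)(=O)N/C(=N\O)Nc3ccc(Cl)cc3)cc2Cl)c(Cl)c1` gives 6 ug/mL. Compound 1 carries the highest number of the three, beyond the scatter from both compound 2 and compound 3. How the core of compound 1 differs from the core of compound 2 is not broken down here.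

From compound 2 to compound 3 the change is chloro in place of hydrogen on an aromatic carbon. Its step is a 2.0-fold lower number from compound 2 to compound 3 (0.30 log units; within the scatter).

Compound 4 `Cc1c(S(=O)(=O)N/C(=N\O)Nc2ccc(Cl)c(Cl)c2)sc2ccc(Cl)cc12` is not yet measured. It differs from compound 1 by chloro in place of hydrogen on an aromatic carbon. Among the measured compounds shown here, this is the same kind of change as the one from compound 2 to compound 3, not the same: in compound 3 the entering chloro sits ortho to a large group and meta to a nitro group, whereas in compound 4 it sits ortho to a chloro group and meta to a large group, on the other side of the shared core.

For the measured compounds named here, the step expected in this assay is a 1.7-fold lower number from compound 1 to compound 4 (0.23 log units; within the scatter), beside the measured one, and it rests on the single precedent a 2.0-fold lower number from compound 2 to compound 3 (0.30 log units; within the scatter), which lies within the scatter, so no shift beyond the scatter is expected. Compound 4 is accordingly estimated at 35 ug/mL, between 15 ug/mL and 75 ug/mL.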

Compound 4, half-maximal inhibitory concentration: > 300 ug/mL
Compound 4: no number, only a limit; the forecaster's own chance of this, stated with the estimate: 5%; middle value at least 8.5-fold (0.93 log units) from the limit.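

In this assay compound 4 gives > 300 ug/mL, which is a limit of the assay and not a number. On these data alone, the chloro addition gives an at least 5.0-fold higher number from compound 1 to compound 4 (0.69 log units; beyond the scatter), so chloro in place of hydrogen on an aromatic carbon does not carry from one core to the other with one size or one direction: the same change on two cores in this assay, a 2.0-fold lower number (0.30 log units; within the scatter) from compound 2 to compound 3 and an at least 5.0-fold higher number (0.69 log units; beyond the scatter) from compound 1 to compound 4, at least 10-fold (1.00 log units) apart, beyond the scatter of two such steps This does not show that the core alone decides the outcome, since the entering chloro stands in a different place on each core, each core offers a single pair, and the full size of the new step stays unknown.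

The compounds shown leave open whether the 3,4-dichlorophenyl group would give a similar result on the core of compound 2, which would help separate the effect of the core from that of the place of the change. They also leave open whether another group in the place taken by chloro in compound 4, such as fluoro, methyl or methoxy, would shift the number as chloro does, or whether this step is peculiar to chloro.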